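This account rests on a few compounds, and the source may have more. Where it says the series, first, only, none or still open, it means among the compounds named here.

Working notes on the series. In an ADME assay on BaF3 cells (Mus musculus) for antiproliferative activity, read by CCK-8 assay, with a stated time of 72 h (a higher number here means a weaker inhibitor of growth, a lower number a stronger inhibitor of growth), compound 1 (`CN1CCN(Cc2ccc(NC(=O)CCSc3ccc4c(/C=C/c5ccccn5)n[nH]c4c3)cc2C(F)(F)F)CC1`) gives 2480 nM and compound 2 (`CCN1CCN(Cc2ccc(NC(=O)CCSc3ccc4c(/C=C/c5ccccn5)n[nH]c4c3)cc2C(F)(F)F)CC1`) gives 840 nM. For the measured compounds named here, compound 2 therefore holds the lower of the two numbers so far.

Compound 3 (`Cc1cn(Cc2ccc(NC(=O)CCSc3ccc4c(/C=C/c5ccccn5)n[nH]c4c3)cc2C(F)(F)F)cn1`) has not yet been measured. It carries 4-methyl-1H-imidazol-1-yl in place of 4-ethylpiperazin-1-yl on a saturated chain carbon bound to an aromatic carbon.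

Going by the values given here, only one measured step bears on this change, and only indirectly. It is a 3.0-fold lower number from compound 1 to compound 2 (0.47 log units; beyond the scatter), made by methyl in place of hydrogen on a saturated chain carbon bound to an amine nitrogen in a ring. That edit lies within the group that compound 3 gives up, so a single small change there already moved the number. Among the compounds with values here, no measured compound carries the entering group, which leaves the direction uncertain. Within the data shown here, a modest step toward a higher number in this assay is expected, starting from the lower of only two values.

The estimated step is a 2.4-fold higher number from compound 2 to compound 3 (0.38 log units; beyond the scatter). Compound 3 is expected at about 2000 nM, with an estimated range of 600 nM to 6000 nM.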

Compound 3, concentration for 50% growth inhibition: 1990 nM
For compound 3 the middle estimate is 1.0-fold (0.00 log units) above the measured one; the measured number falls inside the stated range.
By their numbers in this assay, from the lowest: compound 2; then compounds 3 and 1 (each within the scatter of the next).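

In this assay, the step from the saturated six-membered ring to the aromatic five-membered ring on a saturated chain carbon bound to an aromatic carbon is a 2.4-fold higher number from compound 2 to compound 3 (0.37 log units; beyond the scatter), which is beyond the scatter, so 4-ethylpiperazin-1-yl holds an edge over 4-methyl-1H-imidazol-1-yl at this position. Measured against 4-methylpiperazin-1-yl, the same exchange gives a 1.2-fold lower number from compound 1 to compound 3 (0.10 log units; within the scatter), which is within the scatter, so the reading of the ring exchange depends on which piperazine serves as the reference, and among the three compounds only compound 2 stands apart. Nothing available explains why the two exchanges read differently.

The compounds shown leave open whether the methyl on the imidazole contributes anything, which the unsubstituted 1H-imidazol-1-yl group would test, and whether a saturated ring with a different hetero atom, such as morpholin-4-yl, falls with compound 2 or with compound 3. They also leave open whether a longer chain on the piperazine, as in 4-propylpiperazin-1-yl, would continue the step seen from methyl to ethyl.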